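This account rests on a few compounds, and the source may have more. Where it says the series, first, only, none or still open, it means among the compounds named here.

Compound 2, `Cn1nc(Cc2ccc(Cl)cc2)c2ccccc2c1=O`, gives in a functional assay on aorta with Alpha-1D adrenergic receptor (Rattus norvegicus) as the target (a lower number here means that less compound is needed, a higher number that more compound is needed for the effect), 430 nM. Compound 1, `COc1ccc(Cc2nn(C)c(=O)c3ccccc23)cc1`, gives in this assay < 100000 nM, which is a limit of the assay and not a number. Compound 3, `O=c1c2ccccc2c(Cc2ccc(Cl)cc2)nn1-c1ccc(Br)cc1`, gives in this assay > 30000 nM, again a limit rather than a number.

Within the data shown here, compound 2 therefore stands as the only real number among the three values; the other two are limits. The unmeasured compound 4, `Cn1nc(Cc2ccc(Cl)c(Cl)c2)c2ccccc2c1=O`, differs from compound 2 by a single change: chloro in place of hydrogen on an aromatic carbon. Two measured steps start or end at compound 2. The step that the limit leaves unreadable from compound 1 to compound 2 would be the closer comparison, since it also alters a group on that six-membered aromatic ring of carbon only, but its size cannot be read because of the limit of < 100000 nM in this assay, at which 1 of the 3 values shown sits. The step of an at least 69-fold higher number from compound 2 to compound 3 (1.84 log units; beyond the scatter) is large, yet it changes the group on the aromatic nitrogen, not on this ring. Among the measured compounds shown here, no measured step speaks directly to adding a chloro group here. The expected step of a 1.1-fold lower number from compound 2 to compound 4 (0.03 log units; within the scatter) is therefore small, within the scatter. Compound 4 is estimated at 400 nM, with a range from 100 nM to 1600 nM.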

Compound 4, half-maximal effective concentration: 4900 nM
Estimate against measurement, compound 4: 12-fold (1.09 log units) below; the whole stated range lies below it.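

In this assay a chloro in place of hydrogen, ortho to a chloro group and meta to a large group, gives an 11-fold higher number from compound 2 to compound 4 (1.06 log units; beyond the scatter), so more compound is needed for the effect. Among these compounds, the earlier change on this six-membered aromatic ring, methoxy to chloro, could not be read, so this is the first readable sign that the ring responds to a change, and here a single added heavy atom is enough. Nothing shown accounts for the size of this step.

As far as these compounds go, whether a smaller fluoro or a methyl group on the same carbon would give a step of similar size stays open. So does the effect of an amine or a hydroxyl group there, and whether any group on this carbon could lower the number instead of raising it.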